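This account rests on a few compounds, and the source may have more. Where it says the series, first, only, none or still open, it means among the compounds named here.

Three compounds share one core and differ only in what sits on the outer six-membered aromatic ring of carbon only. Compound 1 is `O=c1[nH]c2ccc(-c3csc(-c4ccccc4)n3)cc2o1`. In an assay on isolated protein for inhibition of protein phosphatase 1D (Homo sapiens), read by malachite green (a lower number here means a stronger inhibitor, a higher number a weaker inhibitor), compound 1 gives < 20000 nM, which is a limit of the assay rather than a number. Compound 2 is `O=c1[nH]c2ccc(-c3csc(-c4ccc(Cl)cc4)n3)cc2o1`, carrying chloro in place of hydrogen on an aromatic carbon. In this assay compound 2 gives < 20000 nM, again a limit. The step that the two limits leave unreadable from compound 1 to compound 2 therefore cannot be read. Compound 3 is `O=c1[nH]c2ccc(-c3csc(-c4ccc(F)c(F)c4)n3)cc2o1`. In this assay compound 3 gives < 20000 nM, once more a limit. Going by the values given here, compound 3 thus stands where every value so far stands, at the limit of < 20000 nM in this assay, at which 3 of the 3 values shown sit, and nothing separates it from compound 1 or compound 2.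

Compound 4 is `Cc1cc(-c2nc(-c3ccc4[nH]c(=O)oc4c3)cs2)ccc1F`. It differs from compound 3 by methyl in place of fluoro on an aromatic carbon. Among the compounds with values here, the only measured step that bears on such a swap on this ring is the one from compound 1 to compound 2, and its size is not readable. No direction or size can be expected for this assay beyond the scatter. Compound 4 is estimated at 5000 nM, with a range from 500 nM to 20000 nM. The expected step is a step that the limit leaves unreadable from compound 3 to compound 4.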

Compound 4, half-maximal inhibitory concentration: < 20000 nM
Compound 4 gave a limit, no number; the forecaster's own chance of this, stated with the estimate: 70%; the middle value is on the limit's open side.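

In this assay, compound 3 and compound 4 both give a limit of the assay rather than a number, so the swap of fluoro for methyl between them cannot be read and yields no new step: the limit of < 20000 nM in this assay, at which 4 of the 4 values shown sit.

The compounds shown leave open how strongly each one actually inhibits the enzyme, and whether any change on the outer ring alters that strength.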